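The source may report more compounds than this note shows. Statements on the series, on what has been measured and on what is new or still open speak of the compounds shown alone.

Three compounds have been measured in a functional assay on the whole organism with Rattus norvegicus as the target, with a stated time of 4 h, at a dose of 40 mg/kg by the intraperitoneal route; a lower number here means less inhibition, a higher number more inhibition at the dose given (going by the name of the read-out):
compound 1 `Cc1cn2cccc(OCc3ccccc3)c2n1` gives 62%;
compound 2 `Cc1nc2c(OCc3ccccc3)cccn2c1C(N)=O` gives 42%;
compound 3 `Cc1nc2c(OCc3ccccc3)cccn2c1CCC#N` gives 40%.

Compound 3 sits at the low end of the three numbers, but its gap to compound 2 lies within the scatter, so the two cannot be told apart; only compound 1 stands clearly higher, as the step of a number 22 percentage points lower from compound 1 to compound 3 (beyond the scatter) shows. Compound 4 `[C-]#[N+]Cc1c(C)nc2c(OCc3ccccc3)cccn12` has not yet been measured. It differs from compound 3 in one place: a group of 2 heavy atoms (1 carbon, 1 nitrogen; no ring) in place of a group of 3 heavy atoms (2 carbon, 1 nitrogen; no ring), on a saturated chain carbon bound to an aromatic carbon. For the measured compounds named here, no measured step alters a group inside a side chain in this way. The nearest guides are a number 20 percentage points lower from compound 1 to compound 2 (beyond the scatter) and a number 22 percentage points lower from compound 1 to compound 3 (beyond the scatter), both modest when a group replaces hydrogen on an aromatic carbon, and a number 2 percentage points lower from compound 2 to compound 3 (within the scatter), an exchange of one such group for another that stayed within the scatter. An exchange of one small group for another is therefore expected to move this assay little, if at all. Compound 4 is expected to give about 40%, between 28% and 55%. The expected step of no change at the digits printed from compound 3 to compound 4 (within the scatter) is estimated to stay within the scatter.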

Compound 4, a percentage reported as inhibition, in the whole organism at one dose (the size of the read-out at that dose, not a potency): 96%
Estimate against measurement, compound 4: 56 percentage points below; measured number outside the range, above it.
By their numbers in this assay, from the lowest: compounds 3 and 2 (each within the scatter of the next); then compound 1; then compound 4.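

In this assay, the side chain turns out to be far more sensitive than the earlier exchange of carbamoyl for 2-cyanoethyl suggested: a group of 2 heavy atoms in place of cyanomethyl, on a saturated chain carbon bound to an aromatic carbon, gives a number 56 percentage points higher from compound 3 to compound 4 (beyond the scatter). The other comparisons agree, with a number 54 percentage points higher from compound 2 to compound 4 (beyond the scatter) and a number 34 percentage points higher from compound 1 to compound 4 (beyond the scatter), so while carbamoyl and 2-cyanoethyl both sit lower than hydrogen on the aromatic carbon, the side chain of compound 4 is the only one shown that sits higher. Nothing available explains this rise.

As far as these compounds go, whether an amine, a carboxylic acid or a longer chain at this place would also keep the number high remains open. From the compounds shown here alone, the read-out comes from one dose and one time, so how potent compound 4 is also stays unknown.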